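A few compounds are considered here, and "the series" means these few. Any claim that something is new, unique, unknown or untested is made for them only; others in the source may bear on it.

Two close analogues open this account. Compound 1, `COc1ccc(-c2cc3c(OC)ccc(OC)c3nc2O)cc1`, was examined in a functional assay on U-87MG ATCC cells for cytotoxicity against U-87 MG (Homo sapiens), read by colorimetric assay and MTT assay (on this read-out higher numbers stand for weaker inhibition and lower numbers for stronger inhibition), where compound 1 gives 10000 nM. Compound 2, `COc1ccc(-c2cc3c(OC)cc(OC)cc3n(C)c2=O)cc1`, carries the shared core with a methyl on the aromatic nitrogen and a methoxy pattern that differs from that of compound 1. In this assay compound 2 gives 10000 nM, which stands level with the value of compound 1 at the digits shown, the two being within the scatter of each other. Against this flat background the next compound is compound 3, `COc1ccc(-c2cc3c(OC)cc(OC)cc3n(CC#N)c2=O)cc1`, not yet measured in this assay. It differs from compound 2 by cyano in place of hydrogen on a saturated chain carbon bound to an aromatic nitrogen, so a methyl becomes a cyanomethyl on the aromatic nitrogen. Among the compounds with values here, no step between measured compounds is available to judge this change, and neither of the two measured compounds gives any hint of movement. The step of no change at the digits printed from compound 2 to compound 3 (within the scatter) is therefore expected to stay within the usual scatter, with no clear direction. On that basis compound 3 is estimated at 10000 nM, with a range from 4000 nM to 30000 nM.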

Compound 3, half-maximal inhibitory concentration: 10000 nM
Beside the measured number, compound 3's estimate shows no gap at the digits printed, and the stated range covers the measured number.
By their numbers in this assay, from the lowest: compounds 1, 2 and 3 (each within the scatter of the next).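

In this assay, within the data shown here, the read-out shows no change at the digits printed from compound 2 to compound 3 (within the scatter) for the exchange of methyl for cyanomethyl on the aromatic nitrogen, and this is the first step in the account that can be read at a single place. For this pair, then, cyano in place of hydrogen on a saturated chain carbon bound to an aromatic nitrogen, which brings in a triple bond outside aromatic rings and a hydrogen-bond acceptor, leaves the value where it stood. Nothing shown here bears on why the value stays level.

On these data alone, whether another group on the aromatic nitrogen, such as an amine, a carboxylic acid or a longer chain, would move the value away from that of compound 3 at 10000 nM in this assay remains open. This single pair also leaves open whether the cyano exchange would read the same way on the shared core with a different methoxy pattern.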